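This account rests on a few compounds, and the source may have more. Where it says the series, first, only, none or still open, it means among the compounds named here.

Measured compounds:
compound 1 `N/C(=N\NC(=S)N1CCOCC1)c1ccccn1`, 14%;
compound 2 `Cc1ccnc(/C(N)=N/NC(=S)N2CCOCC2)c1`, 90.6%;
compound 3 `Cc1ccnc(/C(N)=N/NC(=S)N2CCN(c3ccccn3)CC2)c1`, 81%.

In a functional assay on A-375 cells (Homo sapiens) for cytotoxicity, read by MTT assay, with a stated time of 72 h, tested at 100 uM (a lower number here means less inhibition of growth, a higher number more inhibition of growth at the concentration tested), compound 2 gives 90.6%, while compound 1 gives 14%. The change between them is hydrogen in place of methyl on an aromatic carbon, and the step is a number 76.6 percentage points lower from compound 2 to compound 1 (beyond the scatter). Compound 3 gives 81% in this assay; its two values with compound 2 lie within the scatter of each other. The difference between the cores of compound 2 and compound 3 is not broken down here. Compound 4 `N/C(=N\NC(=S)N1CCN(c2ccccn2)CC1)c1ccccn1` has not yet been measured. Its difference from compound 3 is hydrogen in place of methyl on an aromatic carbon, the same change that was made from compound 2 to compound 1. Because the earlier step was a number 76.6 percentage points lower from compound 2 to compound 1 (beyond the scatter), a drop of comparable size is expected, a number 61 percentage points lower from compound 3 to compound 4 (beyond the scatter), though it rests on a single pair. Compound 4 is thus estimated at 20%, between 5% and 60%.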

Compound 4, percent growth inhibition at one concentration: 86.8%
Beside the measured number, compound 4's estimate is 66.8 percentage points below it; measured number above the stated range.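

In this assay, hydrogen in place of methyl on the aromatic carbon opposite the ring nitrogen gives a number 5.8 percentage points higher from compound 3 to compound 4 (within the scatter), so the large drop seen on the other core does not carry over. The result of the change therefore depends on the core it is made on, at least for these two pairs: the same change on two cores in this assay, a number 76.6 percentage points lower (beyond the scatter) from compound 2 to compound 1 and a number 5.8 percentage points higher (within the scatter) from compound 3 to compound 4, 82.4 percentage points apart, beyond the scatter of two such steps What this does not show is why the two cores part, or how the change would behave on any third core, since two pairs cannot settle either point.

The compounds shown leave open what an ethyl group, a methoxy group or a chlorine atom at that same place would do on either core. They also leave open whether an amine there would follow the morpholine-bearing pair or the other one.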